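Para substituent swap on the anilino ring, second pair

This account rests on a few compounds, and the source may have more. Where it says the series, first, only, none or still open, it means among the compounds named here.

Compound 1 `COc1ccc(-c2nn(-c3ccccc3)cc2CNc2ccc(Br)cc2)cc1` and compound 2 `COc1ccc(-c2nn(-c3ccccc3)cc2CNc2ccc(C)cc2)cc1` share one core; compound 3 `Brc1ccc(NCc2cn(-c3ccccc3)nc2-c2ccc(Br)cc2)cc1` and compound 4 `Cc1ccc(NCc2cn(-c3ccccc3)nc2-c2ccc(Br)cc2)cc1` share another. The two cores differ by bromo in place of methoxy on an aromatic carbon. In a functional assay on B16-F10 cells (Mus musculus) for antiproliferative activity, read by MTT assay, with a stated time of 48 h (on this read-out higher numbers stand for weaker inhibition and lower numbers for stronger inhibition), compound 1 gives 8060 nM, compound 2 gives 8380 nM and compound 3 gives 5270 nM. The change from compound 1 to compound 2 is methyl in place of bromo on an aromatic carbon, and it produced a 1.0-fold higher number from compound 1 to compound 2 (0.02 log units; within the scatter). The change of core is reflected in a 1.5-fold lower number from compound 1 to compound 3 (0.18 log units; within the scatter). The change from compound 3 to compound 4 is methyl in place of bromo on an aromatic carbon, the same change as before, at the same kind of place. Compound 4 is expected to show a step of a 1.0-fold higher number from compound 3 to compound 4 (0.02 log units; within the scatter), because the earlier instance gave a 1.0-fold higher number from compound 1 to compound 2 (0.02 log units; within the scatter). Compound 4 is therefore estimated at 5500 nM, expected to fall between 3000 nM and 10000 nM.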

Compound 4, half-maximal inhibitory concentration: 5980 nM
Compound 4: the middle estimate sits 1.1-fold (0.04 log units) below what was measured, within the range that was stated.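

In this assay, the change from 4-bromophenyl to 4-methylphenyl gives a 1.1-fold higher number from compound 3 to compound 4 (0.05 log units; within the scatter), and the step carries over from one core to the other without a difference beyond the scatter: the same change on two cores in this assay, a 1.0-fold higher number (0.02 log units; within the scatter) from compound 1 to compound 2 and a 1.1-fold higher number (0.05 log units; within the scatter) from compound 3 to compound 4, 1.1-fold (0.04 log units) apart, within the scatter of two such steps. The change of core, read with methyl in place of bromo, gives a 1.4-fold lower number from compound 2 to compound 4 (0.15 log units; within the scatter), and it agrees with the same change read with bromo: the same change on two cores in this assay, a 1.5-fold lower number (0.18 log units; within the scatter) from compound 1 to compound 3 and a 1.4-fold lower number (0.15 log units; within the scatter) from compound 2 to compound 4, 1.1-fold (0.04 log units) apart, within the scatter of two such steps. All of these steps lie within the scatter, which shows that neither change moves the number measurably on either core, but does not show that a step of real size would carry over between cores.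

Still open, on these data alone, is whether an amine or a carboxylic acid at this aromatic carbon would give a step beyond the scatter. Also open, as far as these compounds go, is whether such a step would be the same size on both cores.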